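The source may hold more compounds than are shown below. What is called first, only, known or untested is meant among the compounds shown, and "the series" means these compounds.

Measured in a functional assay on LM7 cells (Homo sapiens) for antiproliferative activity, read by MTT assay, with a stated time of 72 h (a higher number here means a weaker inhibitor, a lower number a stronger inhibitor), so far:

compound 1 `COc1ccc2occ(CSC(=S)N3CCCCC3)c(=O)c2c1` gives 4700 nM
compound 2 `O=c1cc(CSC(=S)N2CCCCC2)oc2cc(Cl)ccc12` gives 13800 nM
compound 3 `O=c1c(CSC(=S)N2CCOCC2)coc2cc(Cl)ccc12` gives 6200 nM

Compound 1 has the lowest number of the three. Compound 3 sits within the usual scatter of it, so the two cannot be told apart on these readings. Only compound 2 stands clearly apart, with a higher number in this assay, which means a weaker inhibitor.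

Compound 4 `COc1ccc2occ(CSC(=S)N(C(C)C)C(C)C)c(=O)c2c1` has not yet been measured in this assay. It differs from compound 1 in one place: diisopropylamino in place of piperidin-1-yl on a thiocarbonyl carbon. The group that leaves carries one ring, the group that enters carries none, and both count no hydrogen-bond donors or acceptors. For the measured compounds named here, no measured pair among the three compounds shows a change of this kind, so there is no step to lean on. The expectation is a small step from compound 1 to compound 4, in no direction that would clearly exceed the scatter, namely a 1.2-fold higher number from compound 1 to compound 4 (0.07 log units; within the scatter). Compound 4 is therefore expected to give about 5500 nM in this assay, with a plausible range from 2000 nM to 15000 nM.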

Compound 4, half-maximal inhibitory concentration: 4700 nM
For compound 4 the middle estimate is 1.2-fold (0.07 log units) above the measured one; the measured number falls inside the stated range.
By their numbers in this assay, from the lowest: compounds 1, 4 and 3 (each within the scatter of the next); then compound 2.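

In this assay, the reading for diisopropylamino in place of piperidin-1-yl on a thiocarbonyl carbon is no change at the digits printed from compound 1 to compound 4 (within the scatter). For the compounds shown here, this is the first direct comparison at this position, and it shows that, on the core of compound 1, the ring of the piperidin-1-yl group can give way to an open group with no ring and no measurable change in this assay. No measurement here accounts for this result, so the reason remains unknown.

Still open, on these data alone, is whether a clearly smaller amine such as dimethylamino, or a different ring such as piperazin-1-yl, would give a similar reading on this thiocarbonyl carbon. A single pair also cannot say whether the same swap would give the same result on another core, such as that of compound 2.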